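A few compounds are considered here, and "the series" means these few. Any claim that something is new, unique, unknown or untested is made for them only; others in the source may bear on it.

Measured compounds and their numbers in a functional assay on UACC-62 cells (Homo sapiens) for inhibition, read by sulforhodamine B assay, with a stated time of 48 h; a lower number here means a stronger inhibitor of growth, a higher number a weaker inhibitor of growth:

compound 1, `O=C(Nc1cccc(-n2cc(-c3ccncc3)c(-c3ccc(Cl)c(O)c3)n2)c1)Nc1cccc(C(F)(F)F)c1`, gives 6910 nM
compound 2, `COc1cc(-c2nn(-c3cccc(NC(=O)Nc4cc(C(F)(F)F)cc(C(F)(F)F)c4)c3)cc2-c2ccncc2)ccc1Cl`, gives 1580 nM
compound 3, `COc1cc(-c2nn(-c3cccc(NC(=O)Nc4cccc(C(F)(F)F)c4)c3)cc2-c2ccncc2)ccc1Cl`, gives 1590 nM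

Compound 2 has the lowest of the three numbers, but compound 3 sits within the scatter of it (a 1.0-fold higher number from compound 2 to compound 3 (0.00 log units; within the scatter)), so the two cannot be ranked; compound 1 gives a clearly higher number than either. Compound 4, `O=C(Nc1cccc(-n2cc(-c3ccncc3)c(-c3ccc(Cl)c(O)c3)n2)c1)Nc1cc(C(F)(F)F)cc(C(F)(F)F)c1`, has not yet been measured. It differs from compound 2 in one place: hydrogen in place of methyl on an oxygen on an aromatic ring.

Within the data shown here, one measured step bears directly on this change, in the reverse direction and on a partner carrying one trifluoromethyl rather than two: a 4.3-fold lower number from compound 1 to compound 3 (0.64 log units; beyond the scatter). The step from compound 2 to compound 3 shows that the second trifluoromethyl barely moves the number, so that reversed step is a fair guide. Removing the methyl is therefore expected to raise the number, and the step is estimated as a 4.3-fold higher number from compound 2 to compound 4 (0.63 log units; beyond the scatter). Compound 4 is expected to give about 6800 nM, in a range from 3000 nM to 15000 nM.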

Compound 4, concentration for total growth inhibition: 2190 nM
Compound 4: middle estimate off by 3.1-fold (0.49 log units), on the high side; the measured number lies below the stated range.
By their numbers in this assay, from the lowest: compounds 2, 3 and 4 (each within the scatter of the next); then compound 1.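

Replacing methoxy with hydroxy has no fixed effect in this assay. With two trifluoromethyl groups on the partner ring, the change gives a 1.4-fold higher number from compound 2 to compound 4 (0.14 log units; within the scatter), so its size depends on the rest of the molecule: the same change on two cores in this assay, a 4.3-fold lower number (0.64 log units; beyond the scatter) from compound 1 to compound 3 and a 1.4-fold lower number (0.14 log units; within the scatter) from compound 4 to compound 2, 3.1-fold (0.50 log units) apart, beyond the scatter of two such steps. The second trifluoromethyl also matters only in one setting, giving a 3.2-fold lower number from compound 1 to compound 4 (0.50 log units; beyond the scatter) among the hydroxy compounds, while the methoxy pair shows no readable change: the same change on two cores in this assay, a 1.0-fold higher number (0.00 log units; within the scatter) from compound 2 to compound 3 and a 3.2-fold higher number (0.50 log units; beyond the scatter) from compound 4 to compound 1, 3.1-fold (0.50 log units) apart, beyond the scatter of two such steps.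

These two pairs cannot show whether the same interplay extends to other groups on this oxygen, such as ethyl or a longer chain, or to an amine in place of the hydroxy. Other groups in place of the second trifluoromethyl, such as chlorine or a nitrile, also remain open.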